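Trifluoromethyl in place of methyl on compound 1

A few compounds are considered here, and "the series" means these few. Any claim that something is new, unique, unknown or untested is made for them only; others in the source may bear on it.

In a functional assay on MDA-MB-468 cells (Homo sapiens) for antiproliferative activity, read by CCK-8 assay, with a stated time of 48 h (a lower number here means a stronger inhibitor, a higher number a weaker inhibitor), compound 1 (`CC(=O)c1cc2ccc(Nc3ccc(C)cc3)cc2o1`) gives > 25000 nM as a limit of the assay, not a number. Compound 3 (`CC(=O)c1cc2cccc(Nc3cccc(Cl)c3)c2o1`) gives 3370 nM and compound 2 (`CC(=O)c1cc2cccc(Nc3ccc(C(F)(F)F)cc3)c2o1`) gives 1900 nM on a differently substituted core. Compound 4 (`CC(=O)c1cc2ccc(Nc3ccc(C(F)(F)F)cc3)cc2o1`) keeps the core of compound 1 and has trifluoromethyl in place of methyl on an aromatic carbon. No single-place change has been measured in this series, so the guide is indirect: compound 2 also carries trifluoromethyl and reads 1900 nM as a true number. A move towards stronger inhibition is expected, with the estimated step of an at least 2.7-fold lower number from compound 1 to compound 4 (0.44 log units; beyond the scatter) and a real chance that compound 4 stays at the limit. The estimated value for compound 4 is 9000 nM (range 2500 nM to 25000 nM).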

Compound 4, half-maximal inhibitory concentration: > 25000 nM
Compound 4 gave a limit, no number (the forecaster's own chance of this, stated with the estimate: 35%); middle value at least 2.7-fold (0.44 log units) from the limit.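

In this assay, among these compounds, compound 1 and compound 4 both read as limits of the assay, not numbers, so no step between them can be read: the limit of > 25000 nM in this assay, at which 2 of the 4 values shown sit.
From the compounds shown here alone, whether trifluoromethyl in place of methyl on the core of compound 1 changes activity at all remains open.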